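The source may report more compounds than this note shows. Statements on the series, on what has been measured and on what is new or still open speak of the compounds shown alone.

Measured compounds:

Compound 1, `COc1ccc(C(=O)c2cc(OC)c(OC)c(OC)c2)cc1N`: in a functional assay on COLO 205 cells (Homo sapiens) for cytotoxicity, read by MTT assay, with a stated time of 72 h (a higher number here means a weaker inhibitor, a lower number a stronger inhibitor), compound 1 gives 200 nM.
Compound 2, `COc1ccc(C(=O)c2cc(OC)c(OC)c(OC)c2)cc1NC(=O)/C=C/c1ccc(F)cc1`: in this assay compound 2 gives 3400 nM.
Compound 3, `COc1cc(C(=O)c2cc(OC)c(OC)c(OC)c2)cc(NC(=O)/C=C/c2ccc(F)cc2)c1OC`: in this assay compound 3 gives 3100 nM.

Compound 4, `COc1cc(C(=O)c2cc(OC)c(OC)c(OC)c2)cc(N)c1OC`, has not yet been measured in this assay.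

Compound 4 is made from compound 3 by one change, (hydrogen in place of (2-(4-fluorophenyl)ethenyl)carbonyl on a nitrogen on an aromatic ring). The same change, read from the two structures, turns compound 2 into compound 1, (hydrogen in place of (2-(4-fluorophenyl)ethenyl)carbonyl on a nitrogen on an aromatic ring), and it occurs twice among these four compounds. The two places are described in the same words, so the change is regarded as the same change in both pairs. Among the measured pair it made a large step: a 17-fold lower number from compound 2 to compound 1 (1.23 log units; beyond the scatter).

The two cores differ in one place, (methoxy in place of hydrogen on an aromatic carbon), and this difference by itself made little difference to the read-out: a 1.1-fold lower number from compound 2 to compound 3 (0.04 log units; within the scatter). Compound 3 therefore starts from almost the same number as compound 2, and the step to compound 4 is expected to be of about the same size as the step that this change made before, because a 17-fold lower number from compound 2 to compound 1 (1.23 log units; beyond the scatter). Compound 4 is accordingly expected to give a much lower number than compound 3, with the estimated step of a 16-fold lower number from compound 3 to compound 4 (1.19 log units; beyond the scatter). On this basis compound 4 is estimated at 200 nM in this assay, with the estimate expected to fall between 70 nM and 600 nM.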

Compound 4, half-maximal inhibitory concentration: 4400 nM
Beside the measured number, compound 4's estimate is 22-fold (1.34 log units) below it; measured number outside the range, above it.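

The change did not carry from one core to the other in this assay. Removing the (2-(4-fluorophenyl)ethenyl)carbonyl group gave a 1.4-fold higher number from compound 3 to compound 4 (0.15 log units; within the scatter), which lies within the scatter, so on this core the free amino compound cannot be told apart from its amide, and the step differs clearly from the one seen on the core of compound 1: the same change on two cores in this assay, a 17-fold lower number (1.23 log units; beyond the scatter) from compound 2 to compound 1 and a 1.4-fold higher number (0.15 log units; within the scatter) from compound 3 to compound 4, 24-fold (1.38 log units) apart, beyond the scatter of two such steps

Read the other way, methoxy in place of hydrogen made no measurable difference between the two amides but gave a 22-fold higher number from compound 1 to compound 4 (1.34 log units; beyond the scatter) between the two free amino compounds, so the effect of each change depends on the other: the same change on two cores in this assay, a 1.1-fold lower number (0.04 log units; within the scatter) from compound 2 to compound 3 and a 22-fold higher number (1.34 log units; beyond the scatter) from compound 1 to compound 4, 24-fold (1.38 log units) apart, beyond the scatter of two such steps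

This shows only that, among these four compounds, the step measured on one core could not be transferred to the other; it does not show why the two cores differ, and it gives no general rule for the series, as it rests on a single pair for each change in a single cell assay.

The compounds shown leave open whether a small acyl group on the nitrogen, such as acetyl, would follow compound 1 or compound 4 in its response to the added methoxy. They also leave open whether an ethoxy group or a fluorine atom in place of that methoxy would give the same result on the free amino compounds.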